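This account rests on a few compounds, and the source may have more. Where it says the series, first, only, none or still open, it means among the compounds named here.

Measured compounds:
compound 1 `CC(C)N1CCN(Cc2csc(N)c2C(=O)c2ccc(Cl)cc2)CC1` — -7.4%
compound 2 `Nc1scc(CN2CCN(c3cccc(Cl)c3Cl)CC2)c1C(=O)c1ccc(Cl)cc1` — -77%
compound 3 `Nc1scc(CN2CCN(c3ccccc3C(F)(F)F)CC2)c1C(=O)c1ccc(Cl)cc1` — -60%

All three were tested in a functional assay on CHO cells with adenosine receptor A1 (Homo sapiens) as the target, read by cAMP accumulation and immunoassay, with a stated time of 6 min, tested at 10 uM; on this read-out higher numbers stand for a weaker effect at the one concentration tested and lower numbers for a stronger effect. Compound 3 stands second highest of the three numbers: its nearest neighbour is compound 2, reached by a number 17 percentage points higher from compound 2 to compound 3 (beyond the scatter), and the furthest is compound 1, from which a number 52.6 percentage points lower from compound 1 to compound 3 (beyond the scatter) led to compound 3. Compound 4 `Nc1scc(CN2CCN(c3ccncc3)CC2)c1C(=O)c1ccc(Cl)cc1` has not yet been measured. It differs from compound 3 in one place: pyridin-4-yl in place of 2-(trifluoromethyl)phenyl on an amine nitrogen in a ring.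

Two kinds of measured step bear on this. Putting an aromatic ring in place of isopropyl on the ring nitrogen gave large drops, a number 69.6 percentage points lower from compound 1 to compound 2 (beyond the scatter) and a number 52.6 percentage points lower from compound 1 to compound 3 (beyond the scatter). Exchanging one aromatic ring for another gave only a modest move, a number 17 percentage points higher from compound 2 to compound 3 (beyond the scatter). The step from compound 3 to compound 4 is again an exchange of one aromatic ring for another, so a modest step is expected, with the direction uncertain. For compound 4 the expected value is -45%, within -80% to -10%, corresponding to an expected a number 15 percentage points higher from compound 3 to compound 4 (beyond the scatter).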

Compound 4, a percentage reported as activity, at one concentration (the size of the read-out at that concentration, not a potency): -15%
Beside the measured number, compound 4's estimate is 30 percentage points below it, within the range that was stated.
By their numbers in this assay, from the lowest: compound 2; then compound 3; then compounds 4 and 1 (each within the scatter of the next).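

In this assay, exchanging one aromatic ring for another on this ring nitrogen need not be a small change: pyridin-4-yl in place of 2-(trifluoromethyl)phenyl gave a number 45 percentage points higher from compound 3 to compound 4 (beyond the scatter), and pyridin-4-yl in place of 2,3-dichlorophenyl gave a number 62 percentage points higher from compound 2 to compound 4 (beyond the scatter). An aromatic ring here therefore does not by itself bring the large drop seen with the two substituted phenyl groups, and pyridin-4-yl cannot be told apart from isopropyl, with a number 7.6 percentage points lower from compound 1 to compound 4 (within the scatter). No measurement at hand explains this difference between the rings.

The compounds shown leave open whether the nitrogen in the ring or the loss of the chlorine or trifluoromethyl groups decides the step. Plain phenyl would help separate these two readings, and pyridin-3-yl would test whether the place of the ring nitrogen matters.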